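Cinnamamide series: opening the pyrrolidine of compound 3

A few compounds are considered here, and "the series" means these few. Any claim that something is new, unique, unknown or untested is made for them only; others in the source may bear on it.

Measured so far in an assay on a protein complex for inhibition of CDK8/Cyclin C (Homo sapiens), with a stated time of 1 h, tested at 10 uM; a lower number here means less inhibition, a higher number more inhibition at the concentration tested (going by the name of the read-out):
- compound 1, `CC(C)[C@@H](NC(=O)/C=C/c1ccncc1-c1ccc2ccccc2c1)C(=O)O`: 77%
- compound 2, `O=C(/C=C/c1ccncc1-c1ccc2ccccc2c1)NC1CC1`: 102%
- compound 3, `O=C(O)[C@@H]1CCCN1C(=O)/C=C/c1ccncc1-c1ccc2ccccc2c1`: 67%

Compound 3 gives the lowest of the three numbers in this assay. Its gap to compound 1 is within the scatter, so no order between those two can be claimed; its gap to compound 2 is beyond the scatter, with compound 2 the higher.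

The next compound, compound 4, is `O=C(O)CCNC(=O)/C=C/c1ccncc1-c1ccc2ccccc2c1`. The change from compound 3 is (2-carboxyethyl)amino in place of 2-carboxypyrrolidin-1-yl on a carbonyl carbon.

Among the measured compounds shown here, two measured steps bear on it. The step of a number 35 percentage points lower from compound 2 to compound 3 (beyond the scatter) shows that replacing a secondary amide without a carboxylic acid by the ring-closed carboxy amide cost much. The step of a number 10 percentage points lower from compound 1 to compound 3 (within the scatter), an open-chain carboxy amide against the same ring-closed one, stayed within the scatter. Compound 4 is again an open-chain carboxy amide with an amide hydrogen, so it sits closer to compound 1 than to compound 2 in kind, and the expectation is a small rise over compound 3, possibly within the scatter.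

Compound 4 is therefore expected to give 78%, between 62% and 94%, a step of a number 11 percentage points higher from compound 3 to compound 4 (beyond the scatter) that is estimated rather than measured.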

Compound 4, a percentage reported as inhibition, at one concentration (the size of the read-out at that concentration, not a potency): 91%
For compound 4 the middle estimate is 13 percentage points below the measured one; the measured number falls inside the stated range.
By their numbers in this assay, from the lowest: compounds 3 and 1 (each within the scatter of the next); then compound 4; then compound 2.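

In this assay, the open (2-carboxyethyl)amino group on the carbonyl carbon separates from the ring-closed 2-carboxypyrrolidin-1-yl group, with a number 24 percentage points higher from compound 3 to compound 4 (beyond the scatter), which the earlier open-chain carboxy amide, compound 1, did not do. The open-chain carboxy amides also differ from each other, with a number 14 percentage points higher from compound 1 to compound 4 (beyond the scatter), so the presence of a carboxylic acid does not fix the number at one level, although a number 11 percentage points lower from compound 2 to compound 4 (beyond the scatter) still leaves the cyclopropyl amide with the highest number of the four. No measurement available here accounts for these steps.

The step to compound 4 changes the ring, the defined stereocentre and the amide hydrogen together, and the compounds shown do not separate these; an N-methyl amide of the same open chain would bear on that point. Also open, from the compounds shown here alone, is how the number responds to a longer chain ending in a carboxylic acid, or to a 2-aminoethyl group or the methyl ester of the 2-carboxyethyl group on the same amide-type nitrogen.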